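The source may hold more compounds than are shown below. What is called first, only, known or untested is meant among the compounds shown, and "the series" means these compounds.

Of the compounds shown here, two of a shared core have been tested. Compound 1 `O=C1CSC(c2c(Cl)cccc2Cl)N1CCN1CCCCC1` gives 32% in an ADME assay on Vero cells (Chlorocebus sabaeus) for cytotoxicity, read by neutral red uptake, tested at 394 ug/mL (a higher number here means a weaker effect of the compound at the concentration tested, a lower number a stronger effect), while compound 2 `O=C1CSC(c2ccc([N+](=O)[O-])cc2)N1CCN1CCCCC1` gives 66%. Compound 2 thus stands highest of the two numbers; its nearest neighbour is compound 1, which lies lower by a gap beyond the scatter.

Compound 3 `O=C1CSC(c2ccc(Cl)cc2)N1CCN1CCCCC1` is the next compound in line. Compared with compound 2, the change is chloro in place of nitro on an aromatic carbon. Among the compounds with values here, no measured pair shows this change directly, so the step cannot be read from the existing numbers; compound 1 does carry chloro, but its pattern is not the same as that of compound 3.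

Drawing on the lower value of compound 1 at 32%, compound 3 is expected to give 45%, with a plausible range from 20% to 75%. The expected step from compound 2 is therefore estimated as a number 21 percentage points lower from compound 2 to compound 3 (beyond the scatter), a decrease of moderate size, with real uncertainty about whether it clears the scatter.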

Compound 3, a percentage reported as activity, at one concentration (the size of the read-out at that concentration, not a potency): 28%
The estimate for compound 3 lay 17 percentage points above the measured number; measured number inside the range.
By their numbers in this assay, from the lowest: compounds 3 and 1 (each within the scatter of the next); then compound 2.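

Within the data shown here, putting chloro in place of nitro on an aromatic carbon, para to a large group, gives the first change here made in one place only, and in this assay it amounts to a number 38 percentage points lower from compound 2 to compound 3 (beyond the scatter). With the rest of the molecule held the same, this single position is therefore enough to shift the read-out by a large step, towards a stronger effect of the compound at the concentration tested. Nothing shown here bears on what lies behind this step.

This is one step on one core, so it gives no rule for other cores. It also leaves open where other groups at this position, such as an amine, a carboxylic acid or a methoxy group, would fall relative to compound 2 and compound 3.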